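A few compounds are considered here, and "the series" means these few. Any claim that something is new, unique, unknown or untested is made for them only; others in the source may bear on it.

Measured so far:
Compound 1, `CC(C)(C)OC(=O)CCC(Nc1ccc(CN(CCCc2c(N)nc(N)nc2O)c2ccc([N+](=O)[O-])c(F)c2[N+](=O)[O-])cc1)C(=O)OC(C)(C)C`: 3500 nM
Compound 2, `Nc1nc(N)c(CCCNc2cc(F)c([N+](=O)[O-])cc2[N+](=O)[O-])c(O)n1`: 1100 nM
Compound 3, `CC(C)(C)OC(=O)CCC(Nc1ccc(CN(CCCc2c(N)nc(N)nc2O)c2ccc([N+](=O)[O-])c(F)c2F)cc1)C(=O)OC(C)(C)C`: 36000 nM

All three were tested in a functional assay on CCRF-CEM cells (Homo sapiens) for cytotoxicity, in the absence of a further agent; on this read-out higher numbers stand for weaker inhibition and lower numbers for stronger inhibition. Compound 2 gives the lowest number of the three; its nearest neighbour is compound 1, and the difference between the two cores is not broken down here. Compound 3 differs from compound 1 in one place: fluoro in place of nitro on an aromatic carbon. That single exchange brought a 10-fold higher number from compound 1 to compound 3 (1.01 log units; beyond the scatter).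

The unmeasured compound 4, `Nc1nc(N)c(CCCNc2cc(F)c(F)cc2[N+](=O)[O-])c(O)n1`, relates to compound 2 in the same way: fluoro in place of nitro on an aromatic carbon. The surroundings of the place are not identical, though. In compound 1 the exchanged group sits ortho to a large group, whereas in compound 2 it sits para to a large group, so this is the same kind of change rather than the same one. Because the same kind of change gave a 10-fold higher number from compound 1 to compound 3 (1.01 log units; beyond the scatter), a step of similar size is expected for compound 4, namely a 10-fold higher number from compound 2 to compound 4 (1.00 log units; beyond the scatter). Compound 4 is therefore estimated at 11000 nM, with a likely range from 3000 nM to 40000 nM.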

Compound 4, half-maximal inhibitory concentration: > 100000 nM
Compound 4: a limit, no number; the forecaster's own chance of this, stated with the estimate: 5%; middle value at least 9.0-fold (0.95 log units) away from the limit.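

In this assay compound 4 gives > 100000 nM, which is a limit of the assay and not a number: the limit of > 100000 nM in this assay, at which 1 of the 4 values shown sits.

Putting fluoro in place of nitro gave an at least 90-fold higher number from compound 2 to compound 4 (1.95 log units; beyond the scatter), so the direction is the same on both cores, while the size of the step does not carry over from one core to the other: the same change on two cores in this assay, a 10-fold higher number (1.01 log units; beyond the scatter) from compound 1 to compound 3 and an at least 90-fold higher number (1.95 log units; beyond the scatter) from compound 2 to compound 4, at least 8.8-fold (0.94 log units) apart, beyond the scatter of two such steps

These two pairs do not show why the steps differ, and the full size of the step on the core of compound 2 remains unknown; the exchanged group also sits para to a large group there, and the pairs cannot separate that placement from the other differences between the cores.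

From the compounds shown here alone, it remains open whether an amine or a nitrile in the same place on the core of compound 2 would stay closer to that compound's number than fluoro does. Also open, going by these compounds, is how a longer chain between the two ring systems would alter the size of this step.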